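Swapping the 4-chlorophenyl of compound 1 for trifluoromethyl

The compounds below may be only part of what the source reports. "The series", "measured", "known", "first", "only" and "open" are said of these compounds alone.

Compound 1 `CC(=O)c1ccc(NC(=O)Cn2nc(-c3ccc(Cl)cc3)nc2N)cc1` — 19.8%
Compound 2 `C/C(=N\O)c1ccc(NC(=O)Cn2nc(-c3ccc(Cl)cc3)nc2N)cc1` — 27.8%

In a functional assay on UACC-257 cells (Homo sapiens) for inhibition, read by sulforhodamine B assay, with a stated time of 48 h, tested at 10 uM (on this read-out lower numbers stand for less inhibition of growth and higher numbers for more inhibition of growth at the one concentration tested), compound 1 gives 19.8%, and compound 2 gives 27.8%. Going by the values given here, the only measured step is a number 8 percentage points higher from compound 1 to compound 2 (within the scatter), so the two compounds cannot be told apart and compound 1 stands level with its single neighbour.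

The next compound, compound 3 `CC(=O)c1ccc(NC(=O)Cn2nc(C(F)(F)F)nc2N)cc1`, keeps the rest of compound 1 and changes one group: trifluoromethyl in place of 4-chlorophenyl on an aromatic carbon. The measured step does not bear directly on this change, since compound 2 still carries the 4-chlorophenyl of compound 1. Among the compounds with values here, no measured compound lacks that group, and the data give no size for its removal. Within the data shown here, the step of a number 8 percentage points higher from compound 1 to compound 2 (within the scatter) is the only guide to how far a structural change has moved this assay, so no shift beyond the scatter is expected, with a slight lean downward and wide uncertainty. The expected change is a number 4.8 percentage points lower from compound 1 to compound 3 (within the scatter). For compound 3 the estimated value is 15%, with an expected range from 0% to 32%.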

Compound 3, percent growth inhibition at one concentration: 14.6%
Beside the measured number, compound 3's estimate is 0.4 percentage points above it; measured number inside the range.
By their numbers in this assay, from the lowest: compounds 3, 1 and 2 (each within the scatter of the next, the first and the last beyond it).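

In this assay, the exchange at the aromatic carbon lying between two ring nitrogen atoms gives a number 5.2 percentage points lower from compound 1 to compound 3 (within the scatter). This is the first reading at this position: the 4-chlorophenyl, with a six-membered aromatic ring, can give way to trifluoromethyl, with no ring, without a shift that this read-out separates from the scatter, so neither the ring nor the chlorine is shown to be needed for the modest growth inhibition seen at the one concentration tested. Nothing in the available data explains this outcome.

As far as these compounds go, whether this position tolerates change more widely remains open, since an amine, a carboxylic acid or a longer alkyl chain on the same carbon could still move the number beyond the scatter in either direction. The compounds shown also leave open how trifluoromethyl at this position would behave with the hydroxyimino group of compound 2 in place of the acetyl group, and whether any member of the series reaches strong inhibition of growth.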